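The compounds below may be only part of what the source reports. "The series", "measured", "known", "first", "only" and "open" are said of these compounds alone.

The three measured compounds:

Compound 1, `COc1ccc(/C=C\c2cc(OC)c(OC)c(OC)c2)cc1OCc1ccc(C=O)cc1`: in an ADME assay on NCM460 cells (Homo sapiens) for cytotoxicity, read by CCK-8 assay, with a stated time of 48 h (on this read-out lower numbers stand for stronger inhibition and higher numbers for weaker inhibition), compound 1 gives 41000 nM.
Compound 2, `COc1ccc(/C=C\c2cc(OC)c(OC)c(OC)c2)cc1OCc1ccc(CN2CCCC[C@H]2C(=O)O)cc1`: in this assay compound 2 gives only a limit of the assay, > 50000 nM.
Compound 3, `COc1ccc(/C=C\c2cc(OC)c(OC)c(OC)c2)cc1OCc1ccc(CN2CC[C@H](O)C2)cc1`: in this assay compound 3 gives 51000 nM.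

Compound 2 therefore has no number of its own, only the limit (the limit of > 50000 nM in this assay, at which 1 of the 3 values shown sits). Its neighbours sit close by: the step of an at least 1.2-fold higher number from compound 1 to compound 2 (0.08 log units; that floor lies within the scatter) and the step of a 1.2-fold higher number from compound 1 to compound 3 (0.09 log units; within the scatter) are both within the usual scatter, and the step that the limit leaves unreadable from compound 2 to compound 3 cannot be read because of the limit. All three compounds thus show weak cytotoxicity in this assay, with nothing to separate them.

Compound 4, `COc1ccc(/C=C\c2cc(OC)c(OC)c(OC)c2)cc1OCc1ccc(CN[C@H](C(=O)O)[C@@H](C)O)cc1`, is the next compound in this series. It differs from compound 2 as follows: (1-carboxy-2-hydroxypropyl)amino in place of 2-carboxypiperidin-1-yl on a saturated chain carbon bound to an aromatic carbon. The earlier steps shown here around compound 2 were all within the scatter or unreadable, so no step beyond the scatter is expected in this assay. Compound 4 is therefore expected to give about 52000 nM, with a range from 30000 nM to 90000 nM, quite possibly reported again only as a limit. The expected step from compound 2 to compound 4 is a step that the limit leaves unreadable from compound 2 to compound 4.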

Compound 4, half-maximal inhibitory concentration: > 50000 nM
Compound 4 gave a limit, no number (the forecaster's own chance of this, stated with the estimate: 60%); the middle value lies beyond the limit too.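

At the saturated chain carbon bound to an aromatic carbon, the ring of 2-carboxypiperidin-1-yl gives way to the open-chain (1-carboxy-2-hydroxypropyl)amino, with no ring and more hydrogen-bond donors, yet this assay still yields only a limit for compound 4, not a number. For the compounds shown here, the one comparison that can be read is an at least 1.2-fold higher number from compound 1 to compound 4 (0.08 log units; that floor lies within the scatter), so swapping formyl for this open-chain group also gives no change that stands clear of the scatter. The steps to compound 4 from compound 2 and from compound 3 cannot be read because of the limit: the limit of > 50000 nM in this assay, at which 2 of the 4 values shown sit.

From the compounds shown here alone, how far the true values of compound 2 and compound 4 lie past this limit remains open. Also open, going by these compounds, is whether a small amine such as dimethylamino, or a longer chain ending in a carboxylic acid, would give a value at this place that stands apart from these.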